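The source may report more compounds than this note shows. Statements on the series, on what has been measured and on what is new or still open speak of the compounds shown alone.

Measured in an ADME assay on L132 cells (Homo sapiens) for cytotoxicity, read by MTT assay, with a stated time of 72 h; a lower number here means a stronger inhibitor, a higher number a weaker inhibitor:
- compound 1 `COc1cc(C2=C(c3cc(C)c(OC)c(C)c3)C(O)CC2=O)cc(OC)c1OC`: > 100 ug/mL
- compound 2 `COc1cc(C2=C(c3cc(C)c(OC)c(C)c3)C(OC(C)=O)CC2=O)cc(OC)c1OC`: > 100 ug/mL
- compound 3 `COc1ccc(C2=C(c3cc(OC)c(OC)c(OC)c3)C(=O)CC2O[SiH2]C(C)(C)C)cc1OC`: > 100 ug/mL

Each of these entries is a limit of the assay and not a number. Compound 3 stands at > 100 ug/mL, which is a limit, so it has no numerical place in the series. For the measured compounds named here, the whole series so far comes down to the limit of > 100 ug/mL in this assay, at which 3 of the 3 values shown sit.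

Next is compound 4 `COc1cc(C2=C(c3cc(C)c(OC)c(C)c3)C(O[SiH2]C(C)(C)C)CC2=O)cc(OC)c1OC`, not yet measured in this assay. Its difference from compound 3 is 4-methoxy-3,5-dimethylphenyl in place of 3,4-dimethoxyphenyl on a double-bonded ring carbon. The entering 4-methoxy-3,5-dimethylphenyl is already carried by compound 1 and compound 2.

Going by the values given here, the only measured step is a step that the two limits leave unreadable from compound 1 to compound 2. It gives no size to carry over, as both of its ends are limits. Among the compounds with values here, the one further guide is the value of a compound with the entering group. Compound 2, which carries that group, gives > 100 ug/mL, and this too is a limit.

No step beyond the scatter is therefore expected in this assay, and no direction is expected either. The expected step that the limit leaves unreadable from compound 3 to compound 4 is an estimate that rests on limits alone. A further limit is the most likely report. If a number is obtained, compound 4 is estimated at 130 ug/mL, with an expected range from 70 ug/mL to 250 ug/mL.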

Compound 4, half-maximal inhibitory concentration: > 100 ug/mL
Compound 4: a limit, no number; the forecaster's own chance of this, stated with the estimate: 85%; the middle value is on the limit's open side.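

In this assay compound 4 gives > 100 ug/mL, which is a limit and not a number. The steps to compound 4 from compound 1, compound 2 and compound 3 cannot be read, as both ends of each are limits. The compounds shown leave open whether any of these changes makes a difference at all: the limit of > 100 ug/mL in this assay, at which 4 of the 4 values shown sit.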